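Removing the 3-methylbut-2-en-1-yl group from compound 1

This account rests on a few compounds, and the source may have more. Where it says the series, first, only, none or still open, it means among the compounds named here.

- compound 1 `COc1cc(/C=C/C(=O)c2c(OC)cc(O)c(CC=C(C)C)c2O)ccc1O` measured at 33800 nM in the cell test
- compound 2 `COc1ccc(/C=C/C(=O)c2c(OC)cc(O)c(CC=C(C)C)c2O)cc1OC` measured at 27700 nM in the cell test

For the measured compounds named here, in a functional assay on HeLa cells (Homo sapiens) for inhibition, read by MTT assay, with a stated time of 72 h (on this read-out lower numbers stand for stronger inhibition and higher numbers for weaker inhibition), compound 1 stands level with compound 2 within the scatter, and these are the only two numbers available. Compound 3 `COc1cc(/C=C/C(=O)c2c(O)cc(O)cc2OC)ccc1O` has not yet been measured. It carries hydrogen in place of 3-methylbut-2-en-1-yl on an aromatic carbon at a site ortho to two hydroxy groups and para to a methoxy group. Going by the values given here, the one measured step is a 1.2-fold lower number from compound 1 to compound 2 (0.09 log units; within the scatter) for methyl in place of hydrogen on an oxygen on an aromatic ring. That is a different change and offers no direct guide. A modest move to a higher number in this assay is therefore expected, though on thin evidence. The expected step is a 1.6-fold higher number from compound 1 to compound 3 (0.21 log units; within the scatter) as an estimate only. For compound 3 the estimate is 55000 nM and the expected range runs from 20000 nM to 130000 nM as a working figure.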

Compound 3, half-maximal inhibitory concentration: > 50000 nM
Compound 3: only a limit was reported (the forecaster's own chance of this, stated with the estimate: 15%); the middle value does not contradict the limit.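

For the compounds shown here, compounds 1 and 2 both carry the 3-methylbut-2-en-1-yl group and differ only on an oxygen, whereas compound 3 is the first to show what happens at this aromatic carbon in this assay. For compound 3 the reading is only a limit, > 50000 nM. Hydrogen in place of 3-methylbut-2-en-1-yl gives an at least 1.4-fold higher number from compound 1 to compound 3 (0.17 log units; that floor lies within the scatter), so losing the group brings no lower number, though whether the true change lies beyond the scatter cannot be told: the limit of > 50000 nM in this assay, at which 1 of the 3 values shown sits.

As far as these compounds go, the actual value of compound 3 therefore remains open, and with it the full size of this step. Also open, from the compounds shown here alone, is whether a longer chain, an amine or a carboxylic acid on this aromatic carbon would give a lower or a higher number than the 3-methylbut-2-en-1-yl group.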